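The compounds below may be only part of what the source reports. "The series", "measured", "known", "first", "only" and "open" are said of these compounds alone.

Compound 1, `O=C(NO)c1cccc(-c2cn([C@H]3C[C@H](C(=O)O)N(CCCc4ccccc4)C3)nn2)c1`, is one of three measured members of this small set. In an assay on Sf9 cells for inhibition of histone deacetylase 11 (Homo sapiens), read by fluorescence, tested at 0.5 uM (a higher number here means more inhibition at the concentration tested (going by the name of the read-out), a lower number less inhibition), compound 1 gives < 10%, which is a limit of the assay rather than a number. Compound 2, `O=C(NO)c1cccc(-c2cn([C@H]3C[C@H](C(=O)O)N(Cc4ccccc4)C3)nn2)c1`, carries the change (phenyl in place of phenethyl on a saturated chain carbon bound to an amine nitrogen in a ring). In this assay compound 2 gives < 10%, again a limit of the assay. The step that the two limits leave unreadable from compound 1 to compound 2 therefore cannot be read, because both values sit at the limit of < 10% in this assay, at which 2 of the 3 values shown sit.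

Compound 3, `O=C(/C=C/c1cn([C@H]2C[C@H](C(=O)O)N(CCCc3ccccc3)C2)nn1)NO`, differs from compound 1 in its core: 2-(hydroxycarbamoyl)ethenyl in place of 3-(hydroxycarbamoyl)phenyl on an aromatic carbon. In this assay, for the measured compounds named here, compound 3 gives 20%, the only plain number among the measured values. The step of a number at least 10 percentage points higher from compound 1 to compound 3 (that floor lies within the scatter) is the one readable movement here.

Compound 4, `O=C(/C=C/c1cn([C@H]2C[C@H](C(=O)O)N(Cc3ccccc3)C2)nn1)NO`, has not yet been measured. It is related to compound 3 by phenyl in place of phenethyl on a saturated chain carbon bound to an amine nitrogen in a ring, the same change that joins compound 1 to compound 2, made on the core of compound 3. Since the earlier instance of this change is hidden behind two limits, it gives no size to carry over. The expectation for compound 4 rests on compound 3 at 20% and on the chance that the change leaves that value roughly where it is. A step of about a number 5 percentage points lower from compound 3 to compound 4 (within the scatter) is estimated from compound 3 to compound 4. Compound 4 is therefore expected to give about 15%, with a plausible span from 5% to 30%, in this assay.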

Compound 4, a percentage reported as inhibition, at one concentration (the size of the read-out at that concentration, not a potency): 14%
Compound 4: the middle estimate sits 1 percentage points above what was measured; measured number inside the range.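

In this assay, the exchange of 3-phenylpropyl for benzyl on the core of compound 3 gives a number 6 percentage points lower from compound 3 to compound 4 (within the scatter), so this core does not tell the two chains apart. The same exchange on the core of compound 1 cannot be read, and it therefore offers no size to set beside the new step: the limit of < 10% in this assay, at which 2 of the 4 values shown sit. The exchange of 3-(hydroxycarbamoyl)phenyl for 2-(hydroxycarbamoyl)ethenyl, now seen with the benzyl chain as well, gives a number at least 4 percentage points higher from compound 2 to compound 4 (that floor lies within the scatter), so it points the same way on both cores but does not show a size that carries from one to the other: the same change on two cores in this assay, a number at least 10 percentage points higher (that floor lies within the scatter) from compound 1 to compound 3 and a number at least 4 percentage points higher (that floor lies within the scatter) from compound 2 to compound 4; the limit leaves it open whether they differ.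

All the compounds shown keep the carboxylic acid and end their chain on the amine nitrogen in an unsubstituted phenyl ring, which leaves open what an amide or an ester in place of that acid, or a fluorine or methoxy group on that phenyl ring, would do. Also open, from the compounds shown here alone, is whether a chain longer than 3-phenylpropyl, or a simple alkyl chain with no phenyl ring, would separate the compounds in this assay.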